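Removing the nitro group in a weakly active antiproliferative series

This account rests on a few compounds, and the source may have more. Where it says the series, first, only, none or still open, it means among the compounds named here.

Measured compounds:
Compound 1 `O=[N+]([O-])c1ccc(COc2ccc(Nc3ncnc4cc5c(cc34)OCCOCCO5)cc2)cc1`: in a functional assay on DU-145 cells (Homo sapiens) for antiproliferative activity, read by MTT assay, with a stated time of 72 h (a lower number here means a stronger inhibitor, a higher number a weaker inhibitor), compound 1 gives > 100000 nM, which is a limit of the assay and not a number.
Compound 2 `c1ccc(COc2ccc(Nc3ncnc4cc5c(cc34)OCCOCCO5)cc2)cc1`: in this assay compound 2 gives > 100000 nM, again a limit.
Compound 3 `O=[N+]([O-])c1ccc(COc2ccc(Nc3ncnc4cc5c(cc34)OCCOCCOCCOCCO5)cc2)cc1`: in this assay compound 3 gives > 100000 nM, also a limit.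

Compound 2 arises from compound 1 by hydrogen in place of nitro on an aromatic carbon. The step that the two limits leave unreadable from compound 1 to compound 2 cannot be read, since both values are limits. Compound 3 carries a different core; the difference between the two cores is not broken down here. Compound 4 `c1ccc(COc2ccc(Nc3ncnc4cc5c(cc34)OCCOCCOCCOCCO5)cc2)cc1` stands to compound 3 as compound 2 stands to compound 1, by hydrogen in place of nitro on an aromatic carbon, the same change at the same place. For the measured compounds named here, every value so far sits at the limit of > 100000 nM in this assay, at which 3 of the 3 values shown sit.

The expectation for compound 4 rests on compound 3 sitting at its limit of > 100000 nM. The step from compound 3 to compound 4 is expected to be a step that the limit leaves unreadable from compound 3 to compound 4, in line with the unreadable earlier step. Compound 4 is therefore expected to return another limit, estimated at 200000 nM. The range for compound 4 is estimated as 50000 nM to 1000000 nM.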

Compound 4, half-maximal inhibitory concentration: 8800 nM
Compound 4: the middle estimate sits 23-fold (1.36 log units) above what was measured, outside the stated range (below it).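

In this assay, hydrogen in place of nitro gives an at least 11-fold lower number from compound 3 to compound 4 (1.05 log units; beyond the scatter), so on the core of compound 3 the change produces a large, readable effect. On the core of compound 1 the same change joins two limits of the assay, and that step cannot be read: it may be absent, small or large, so these data neither show that the effect carries from one core to the other nor show that it fails to. Compound 4 alone has a measured number, and the rest of the series gives only limits, not numbers: the limit of > 100000 nM in this assay, at which 3 of the 4 values shown sit.

On these data alone, it stays open whether an amine or a carboxylic acid at the same place on the ring, para to the large group, would keep the value of compound 4 or return to the limit. As far as these compounds go, it also stays open whether a longer chain in the core would move the benzyl compounds any further in this assay.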